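Swapping cyclopropyl for 4-methylphenyl on the triazole

The compounds below may be only part of what the source reports. "The series", "measured", "known", "first", "only" and "open" are said of these compounds alone.

Of the compounds shown here, three sharing one core have been tested in a functional assay on MCF7 cells (Homo sapiens) for antiproliferative activity, read by MTT assay, with a stated time of 72 h; on this read-out higher numbers stand for weaker inhibition and lower numbers for stronger inhibition. Compound 1 `CCCCCc1ccc(-c2cn(C[C@H](O)[C@H]3OC(=O)C(OCc4ccccc4)=C3OCc3ccccc3)nn2)cc1` gives 9010 nM, compound 2 `CC(C)(C)c1cn(C[C@H](O)[C@H]2OC(=O)C(OCc3ccccc3)=C2OCc2ccccc2)nn1` gives 730 nM, and compound 3 `O=C1O[C@H]([C@@H](O)Cn2cc(C3CC3)nn2)C(OCc2ccccc2)=C1OCc1ccccc1` gives 25900 nM. Compound 3 thus sits at the highest number of the three: compound 1 lies nearest, and compound 2 furthest away, as the measured steps show, a 2.9-fold higher number from compound 1 to compound 3 (0.46 log units; beyond the scatter) and a 35-fold higher number from compound 2 to compound 3 (1.55 log units; beyond the scatter). Compound 4 `Cc1ccc(-c2cn(C[C@H](O)[C@H]3OC(=O)C(OCc4ccccc4)=C3OCc3ccccc3)nn2)cc1` differs from compound 3 in one place: 4-methylphenyl in place of cyclopropyl on an aromatic carbon. The most telling measured step is a 2.9-fold higher number from compound 1 to compound 3 (0.46 log units; beyond the scatter), where a 4-pentylphenyl group on that same aromatic carbon gave a lower number than cyclopropyl. As far as these compounds go, since 4-methylphenyl is again a six-membered aromatic ring on the same carbon, a step of similar size in the opposite direction is expected, so that compound 4 should show a lower number than compound 3, a 3.7-fold lower number from compound 3 to compound 4 (0.57 log units; beyond the scatter), though whether the shorter methyl chain behaves like pentyl is unknown. Compound 4 is estimated at 7000 nM, with a range from 2000 nM to 25000 nM.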

Compound 4, half-maximal inhibitory concentration: > 100000 nM
Compound 4: no number, only a limit (the forecaster's own chance of this, stated with the estimate: 5%); middle value at least 14-fold (1.15 log units) away from the limit.
By their numbers in this assay, from the lowest: compound 2; then compound 1; then compound 3. At a limit, above all of these: compound 4.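

In this assay compound 4 gives only a limit, not a number: the limit of > 100000 nM in this assay, at which 1 of the 4 values shown sits. The six-membered aromatic ring does not settle the outcome on this aromatic carbon by itself: with the ring kept, the chain on it matters, as shortening 4-pentylphenyl to 4-methylphenyl gives an at least 11-fold higher number from compound 1 to compound 4 (1.04 log units; beyond the scatter). Nor does a larger group alone bring the number down, since 4-methylphenyl gives an at least 3.8-fold higher number from compound 3 to compound 4 (0.58 log units; beyond the scatter) against the smaller cyclopropyl, while the non-aromatic tert-butyl stays far ahead with an at least 130-fold higher number from compound 2 to compound 4 (2.13 log units; beyond the scatter).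

As far as these compounds go, how the number changes along the chain between methyl and pentyl remains open, for instance with a 4-ethylphenyl or 4-propylphenyl group. Also open, from the compounds shown here alone, is what a plain phenyl ring, or one carrying an amine or a carboxylic acid, would give at this position.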